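Dialkoxybutane series: aryl ether swap toward a fluorinated acid

This account rests on a few compounds, and the source may have more. Where it says the series, first, only, none or still open, it means among the compounds named here.

compound 1 `Cc1cc(C(=O)O)ccc1OCCCCOc1ccc(C(=O)CC(C)C)c(O)c1C`: 42.1%
compound 2 `CCCC(=O)c1ccc(OCCCCOc2ccc(F)c(C(=O)O)c2)c(C)c1O`: 56.9%
compound 3 `Cc1cc(OCCCCOc2ccc(C(=O)CC(C)C)c(O)c2C)ccc1C(=O)O`: 41.9%

In an assay on HEK293 cells for positive allosteric modulation of metabotropic glutamate receptor 3 (Rattus norvegicus), read by thallium flux, with a stated time of 2.5 min (on this read-out lower numbers stand for smaller maximal responses and higher numbers for larger maximal responses), compound 3 shows the lowest of the three numbers; compound 1 lies nearest, within the scatter, and compound 2 lies furthest, beyond it. Within the data shown here, the one measured single-place step, a number 0.2 percentage points lower from compound 1 to compound 3 (within the scatter), is within the scatter and concerns only the methyl position, not the group that changes next. Compound 4 `Cc1c(OCCCCOc2ccc(F)c(C(=O)O)c2)ccc(C(=O)CC(C)C)c1O` carries 3-carboxy-4-fluorophenyl in place of 4-carboxy-3-methylphenyl on an oxygen on a saturated carbon. Among the measured compounds shown here, compound 2 carries the entering 3-carboxy-4-fluorophenyl but differs from compound 3 in more than one place, so its value and that of compound 3 show only that the higher number sits with the fluorinated acid. Compound 4 is therefore expected to give 50%, range 38% to 62%, an expected step of a number 8.1 percentage points higher from compound 3 to compound 4 (within the scatter), leaning upward but uncertain.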

Compound 4, largest response reached (reported as percent of maximum), in percent of the reference or control that the assay uses: 81.7%
Compound 4: the middle estimate sits 31.7 percentage points below what was measured; measured number outside the range, above it.
By their numbers in this assay, from the lowest: compounds 3 and 1 (each within the scatter of the next); then compound 2; then compound 4.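

In this assay the change to 3-carboxy-4-fluorophenyl on an oxygen on a saturated carbon gives a number 39.8 percentage points higher from compound 3 to compound 4 (beyond the scatter) and also a number 39.6 percentage points higher from compound 1 to compound 4 (beyond the scatter) so the two methyl-bearing acids, alike in number, both fall well short of the fluorinated acid. The other end also matters: methyl in place of hydrogen on a saturated chain carbon bound to two saturated chain carbons gives a number 24.8 percentage points higher from compound 2 to compound 4 (beyond the scatter) with the fluorinated acid held constant. No measurement shown gives a reason for these steps.

Whether the fluorine or the placing of the carboxylic acid accounts for the rise stays open. Also open, on these data alone, is whether a longer chain at the other end, or an amine in place of the carboxylic acid, would hold the number.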